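The source may report more compounds than this note shows. Statements on the series, on what has been measured and on what is new or still open speak of the compounds shown alone.

Measured so far in a functional assay on Ehrlich cells (Mus musculus) for cytotoxicity, read by trypan blue exclusion; on this read-out lower numbers stand for stronger inhibition and higher numbers for weaker inhibition:
Compound 1 `N#Cc1c(N)[n+]([O-])c2ccc(Cl)cc2[n+]1[O-]` gives 13.5 ug/mL.
Compound 2 `CNc1c(C#N)[n+]([O-])c2cc(Cl)ccc2[n+]1[O-]` reaches only the limit of the measurement, > 100 ug/mL.
Compound 3 `Cc1c(C(=O)N=[N+]=[N-])[n+]([O-])c2cc(Cl)ccc2[n+]1[O-]` likewise reaches only the limit of the measurement, > 100 ug/mL.

Two of the three values sit at the limit of > 100 ug/mL in this assay, at which 2 of the 3 values shown sit, and compound 3 is one of them, so it stands among the limit values rather than among the numbers. Among the measured compounds shown here, the single measured step, an at least 7.4-fold higher number from compound 1 to compound 2 (0.86 log units; beyond the scatter), concerns a change at a ring nitrogen and does not touch the position altered here. Compound 4 `COc1ccc2c(c1)[n+]([O-])c(C(=O)N=[N+]=[N-])c(C)[n+]2[O-]` differs from compound 3 by methoxy in place of chloro on an aromatic carbon. For the measured compounds named here, no measured step bears on this exchange, so no shift beyond the scatter can be grounded, and a value that again reaches only the limit is the plainer expectation. Compound 4 is estimated at 100 ug/mL, between 40 ug/mL and 300 ug/mL. The step expected from this, a number no higher from compound 3 to compound 4 (the limit leaves the size open), is none beyond the scatter.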

Compound 4, half-maximal inhibitory concentration: 12.5 ug/mL
Compound 4: the middle estimate sits 8.0-fold (0.90 log units) above what was measured; measured number below the stated range.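

In this assay, methoxy in place of chloro on this aromatic carbon brings an at least 8.0-fold lower number from compound 3 to compound 4 (0.90 log units; beyond the scatter), so this position, untouched by the earlier step, can clearly move the read-out. That size is only a minimum, because one end of the step is a limit: the limit of > 100 ug/mL in this assay, at which 2 of the 4 values shown sit.

Whether the change depends on methoxy itself stays open, since the compounds shown carry only chloro or methoxy at this carbon. An ethoxy group or an amine there would show how specific the effect is.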